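Chloro in Place of Methoxy: an Expected Small Step

The compounds below may be only part of what the source reports. "The series", "measured", "known", "first", "only" and "open" are said of these compounds alone.

Of the compounds shown here, three sharing one core have been measured in a functional assay on HeLa cells (Homo sapiens) for antiproliferative activity, read by CCK-8 assay, with a stated time of 72 h; a higher number here means a weaker inhibitor, a lower number a stronger inhibitor. Compound 1 `COc1ccc(SCc2ccc(C(=O)Nc3ccccc3N)cc2)cc1` gives 2390 nM, the second highest of the three numbers. Compound 2 `Cc1cc(C)cc(SCc2ccc(C(=O)Nc3ccccc3N)cc2)c1` gives 2090 nM, and compound 3 `CCc1ccc(SCc2ccc(C(=O)Nc3ccccc3N)cc2)cc1` gives 3800 nM. All steps between them stay small: a 1.1-fold lower number from compound 1 to compound 2 (0.06 log units; within the scatter), a 1.6-fold higher number from compound 1 to compound 3 (0.20 log units; within the scatter) and a 1.8-fold higher number from compound 2 to compound 3 (0.26 log units; within the scatter). Compound 4 `Nc1ccccc1NC(=O)c1ccc(CSc2ccc(Cl)cc2)cc1` differs from compound 1 by chloro in place of methoxy on an aromatic carbon. Among the measured compounds shown here, no measured step puts chloro there; the closest guide is a 1.6-fold higher number from compound 1 to compound 3 (0.20 log units; within the scatter), where ethyl replaced methoxy, and it stayed within the scatter, as did the other two steps. A step of no more than the scatter is therefore expected, a 1.0-fold higher number from compound 1 to compound 4 (0.00 log units; within the scatter). Compound 4 is estimated at 2400 nM, with a range from 1200 nM to 5000 nM.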

Compound 4, half-maximal inhibitory concentration: 12700 nM
For compound 4 the middle estimate is 5.3-fold (0.72 log units) below the measured one; the whole stated range lies below it.
By their numbers in this assay, from the lowest: compounds 2, 1 and 3 (each within the scatter of the next); then compound 4.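

At this place, on an aromatic carbon para to a large group, the choice of group can matter after all: in this assay chloro gives a 5.3-fold higher number from compound 1 to compound 4 (0.73 log units; beyond the scatter) and a 3.3-fold higher number from compound 3 to compound 4 (0.52 log units; beyond the scatter), both beyond the scatter, although ethyl and methoxy stayed within it. The comparison with a differently substituted ring points the same way, with a 6.1-fold higher number from compound 2 to compound 4 (0.78 log units; beyond the scatter). Nothing measured here explains why chloro stands apart from the other groups.

As far as these compounds go, whether fluoro or bromo would follow chloro remains open, as does the behaviour of an amine or a carboxylic acid at this place.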